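A few compounds are considered here, and "the series" means these few. Any claim that something is new, unique, unknown or untested is made for them only; others in the source may bear on it.

Compound 1 `CN(C)CCn1c(=O)sc2cc(NS(=O)(=O)c3ccccc3)ccc21` and compound 2 `O=c1sc2cc(NS(=O)(=O)c3ccccc3)ccc2n1CCN1CCCC1` share a core; compound 3 `CN(C)CCn1c(=O)sc2cc(S(=O)(=O)N(C)c3ccccc3)ccc21` and compound 4 `CN(c1ccccc1)S(=O)(=O)c1ccc2c(c1)sc(=O)n2CCN1CCCC1` share another, and the difference between the two cores is not broken down here. In an assay on HEK293 cells for displacement of a labelled ligand from 5-hydroxytryptamine receptor 6 (Homo sapiens), read by radioligand binding, with a stated time of 60 min, tested at 100 nM (a higher number here means more inhibition at the concentration tested (going by the name of the read-out), a lower number less inhibition), compound 1 gives 5% and compound 2 gives 11%. The change pyrrolidin-1-yl in place of dimethylamino on a saturated chain carbon, two bonds along the chain from an aromatic nitrogen made the step of a number 6 percentage points higher from compound 1 to compound 2 (within the scatter). In this assay compound 3 gives 5%, level with compound 1 at the digits read, within the scatter. The change pyrrolidin-1-yl in place of dimethylamino on a saturated chain carbon, two bonds along the chain from an aromatic nitrogen is the same change on the other core, and the same kind of step is expected: from compound 3 to compound 4 the step is estimated as a number 4 percentage points higher from compound 3 to compound 4 (within the scatter), resting on the near-flat step from compound 1 to compound 2 and on compound 3 giving 5%. Compound 4 is therefore expected in this assay to give about 9%, between 0% and 25%.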

Compound 4, a percentage reported as inhibition, at one concentration (the size of the read-out at that concentration, not a potency): 10%
Compound 4: middle estimate off by 1 percentage points, on the low side; low and high end bracket the measured number.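

In this assay pyrrolidin-1-yl in place of dimethylamino gives a number 5 percentage points higher from compound 3 to compound 4 (within the scatter) and the change reads alike on both cores: the same change on two cores in this assay, a number 6 percentage points higher (within the scatter) from compound 1 to compound 2 and a number 5 percentage points higher (within the scatter) from compound 3 to compound 4, 1 percentage points apart, within the scatter of two such steps

What carries from one core to the other is a near-flat result, with neither step distinguishable from no change. This does not show that the change raises inhibition on either core, nor how it would carry over on a core giving much higher readings.

Open, on these data alone, is whether piperidine or morpholine in place of pyrrolidin-1-yl would give a reading beyond the scatter on either core. The same holds for a longer chain than 2-(pyrrolidin-1-yl)ethyl.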